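Adding a Side Chain to an Inactive Acylguanidine

A few compounds are considered here, and "the series" means these few. Any claim that something is new, unique, unknown or untested is made for them only; others in the source may bear on it.

In a functional assay on Hs 683 cells (Homo sapiens) for inhibition, read by MTT assay, with a stated time of 72 h (a lower number here means a stronger inhibitor of growth, a higher number a weaker inhibitor of growth), compound 1 (`CC(C)=CC(=O)NC(=N)N`) gives > 100000 nM, which is a limit of the assay and not a number. Its true position is therefore unknown, and any comparison with it can only be loose. Compound 2 (`C=C1CCCC(C)(C)[C@@H]1CC/C(C)=C/C(=O)NC(=N)NC(=O)C=C(C)C`) gives a measured value of 18100 nM in this assay, showing that a compound in this small set can register a number.

Compound 3 (`CC(C)=CCC/C(C)=C/C(=O)NC(=N)N`) is built from compound 1 by placing 3-methylbut-2-en-1-yl in place of hydrogen on a saturated chain carbon bound to a double-bonded chain carbon. Going by the values given here, no measured pair isolates this change, so its size must be judged with little support. A modest move towards stronger growth inhibition seems the most likely outcome, although compound 3 could also remain at the limit of the assay. The expected change is an at least 2.0-fold lower number from compound 1 to compound 3 (0.30 log units; that floor lies within the scatter). For compound 3, the estimated value in this assay is 50000 nM, with an expected range of 20000 nM to 100000 nM.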

Compound 3, concentration for 50% growth inhibition: 39400 nM
Estimate against measurement, compound 3: 1.3-fold (0.10 log units) above; the range from low to high includes it.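

Compound 3 gives the first measured view of this position. In this assay, 3-methylbut-2-en-1-yl in place of hydrogen on a saturated chain carbon bound to a double-bonded chain carbon brings the read-out off the limit, a change of an at least 2.5-fold lower number from compound 1 to compound 3 (0.40 log units; beyond the scatter). Going by these compounds alone, compounds 1 and 2 offered no comparison of a change in one place, so this is the first evidence that adding a chain here can bring a measurable result. The step gives only a floor and not a full size, because compound 1 stands at a limit and not at a number: the limit of > 100000 nM in this assay, at which 1 of the 3 values shown sits.

One added group is a single point, and the compounds shown cannot tell whether a plain ethyl group, a longer chain, or a chain carrying an amine or a carboxylic acid would give a lower or a higher number at this position. They also leave open whether the double bond inside 3-methylbut-2-en-1-yl matters, which a saturated chain of the same length would test.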